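The source may report more compounds than this note shows. Statements on the series, on what has been measured and on what is new or still open speak of the compounds shown alone.

Compound 1 `NS(=O)(=O)c1ccccc1-c1cnc(C(=O)CCCCCCc2ccccc2)o1`: 1500 nM
Compound 2 `N#Cc1cccc(-c2cnc(C(=O)CCCCCCc3ccccc3)o2)c1`: 15 nM

In an assay (Rattus norvegicus) for inhibition of Fatty-acid amide hydrolase 1 (Homo sapiens) (on this read-out lower numbers stand for stronger inhibition and higher numbers for weaker inhibition), compound 2 gives 15 nM, the lowest of the two numbers, while compound 1 gives 1500 nM, a gap beyond the usual scatter. Compound 3 `CN(C)C(=O)c1cnc(C(=O)CCCCCCc2ccccc2)o1` is not yet measured and differs from compound 2 in one place: dimethylcarbamoyl in place of 3-cyanophenyl on an aromatic carbon. For the measured compounds named here, no step between measured compounds covers such a change, so the expectation rests only on the wide spread between compound 1 and compound 2. The step is expected to go toward weaker inhibition, a 10-fold higher number from compound 2 to compound 3 (1.00 log units; beyond the scatter). Compound 3 is estimated at 150 nM, with a range from 30 nM to 1000 nM.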

Compound 3, inhibition constant: 2 nM
For compound 3 the middle estimate is 75-fold (1.88 log units) above the measured one; the measured number lies below the stated range.
By their numbers in this assay, from the lowest: compound 3; then compound 2; then compound 1.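

Replacing 3-cyanophenyl with dimethylcarbamoyl on the aromatic carbon next to the ring oxygen gives a 7.5-fold lower number from compound 2 to compound 3 (0.88 log units; beyond the scatter) in this assay and shows that this position needs no aromatic ring for strong inhibition. A group with no ring and fewer heavy atoms does better here than 3-cyanophenyl. No available evidence explains this gain.

The compounds shown leave open whether the gain depends on the carbonyl or on the two methyl groups. They also leave open how a carboxylic acid or a methyl ester would compare at this position.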